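The compounds below may be only part of what the source reports. "The series", "measured", "known", "first", "only" and "open" are said of these compounds alone.

Of the compounds shown here, three sharing one core have been measured in an assay on isolated protein for displacement of a labelled ligand from metabotropic glutamate receptor 5 (Homo sapiens), with a stated time of 60 min, tested at 1 uM; a lower number here means less inhibition, a higher number more inhibition at the concentration tested (going by the name of the read-out). Compound 1 `Cc1ccc(S(=O)(=O)c2cnc3cc(F)ccc3c2N2CCC(C)CC2)cc1C` gives 90%, compound 2 `Cc1cc(C)cc(S(=O)(=O)c2cnc3cc(F)ccc3c2N2CCC(C)CC2)c1` gives 80%, and compound 3 `CC1CCN(c2c(S(=O)(=O)c3ccc(Cl)c(Cl)c3)cnc3cc(F)ccc23)CC1` gives 94%. The number for compound 3 is the highest shown, yet its separation from compound 1, a number 4 percentage points higher from compound 1 to compound 3 (within the scatter), lies within the scatter, and only its separation from compound 2, a number 14 percentage points higher from compound 2 to compound 3 (beyond the scatter), lies beyond it. Compound 4 `COc1ccc(S(=O)(=O)c2cnc3cc(F)ccc3c2N2CCC(C)CC2)cc1OC` is not yet measured; it differs from compound 3 only in the group on the sulfonyl sulfur: 3,4-dimethoxyphenyl in place of 3,4-dichlorophenyl on a sulfonyl sulfur. Every measured step swaps that same group, and none of them was large: a number 10 percentage points lower from compound 1 to compound 2 (within the scatter) stayed within scatter, the biggest being the modest a number 14 percentage points higher from compound 2 to compound 3 (beyond the scatter). For the measured compounds named here, no measured step involves a methoxy-bearing group, so the expected step of a number 12 percentage points lower from compound 3 to compound 4 (beyond the scatter) is a small decrease with wide uncertainty. Compound 4 is expected to give 82%, between 60% and 95%.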

Compound 4, a percentage reported as inhibition, at one concentration (the size of the read-out at that concentration, not a potency): 83%
The estimate for compound 4 lay 1 percentage points below the measured number, within the range that was stated.
By their numbers in this assay, from the lowest: compounds 2, 4, 1 and 3 (each within the scatter of the next, the first and the last beyond it).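

For the compounds shown here, compound 4 puts the first oxygen-bearing group on the sulfonyl sulfur, and in this assay the change from 3,4-dichlorophenyl to 3,4-dimethoxyphenyl gives a number 11 percentage points lower from compound 3 to compound 4 (beyond the scatter), a modest step. The same group cannot be separated from either dimethylphenyl group, with a number 7 percentage points lower from compound 1 to compound 4 (within the scatter) and a number 3 percentage points higher from compound 2 to compound 4 (within the scatter), so with this larger group carrying hydrogen-bond acceptors the inhibition in this assay is level with that of both dimethylphenyl compounds. Nothing shown gives a reason for these steps. Still open, on these data alone, is how an amine or a carboxylic acid on this phenyl ring would read out. Changes elsewhere on the shared core also remain open.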